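This account rests on a few compounds, and the source may have more. Where it says the series, first, only, none or still open, it means among the compounds named here.

- compound 1 `O=C(O)CN1C(=O)/C(=C/c2nc3ccccc3n2Cc2ccccc2F)SC1=S`: 1230 nM
- compound 2 `O=C(O)CN1C(=O)/C(=C/c2nc3ccccc3n2Cc2ccc(F)c(F)c2)SC1=S`: 7250 nM

In a functional assay on Raji cells (Homo sapiens) for cytotoxicity, read by MTT assay, with a stated time of 48 h (a lower number here means a stronger inhibitor, a higher number a weaker inhibitor), compound 1 gives the lower of the two numbers, 1230 nM. For the measured compounds named here, the only measured step, a 5.9-fold higher number from compound 1 to compound 2 (0.77 log units; beyond the scatter), is modest and places 3,4-difluorophenyl in place of 2-fluorophenyl. Compound 3 `COc1ccc2c(c1)nc(/C=C1\SC(=S)N(CC(=O)O)C1=O)n2Cc1ccccc1F` keeps the 2-fluorophenyl and changes elsewhere: methoxy in place of hydrogen on an aromatic carbon. The measured step lies at a different place, so it bears only indirectly, showing the size a single change has reached here. Nothing measured shows what methoxy does. Going by the values given here, a step no larger than that one is therefore expected in this assay, with a slight lean towards a higher number, as only one other compound has been compared with compound 1 at 1230 nM and it gives a higher number. The estimated step is a 1.8-fold higher number from compound 1 to compound 3 (0.25 log units; within the scatter). For compound 3 the estimate is 2200 nM, with an expected range of 700 nM to 7000 nM.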

Compound 3, half-maximal inhibitory concentration: 11500 nM
Beside the measured number, compound 3's estimate is 5.2-fold (0.72 log units) below it; measured number outside the range, above it.
By their numbers in this assay, from the lowest: compound 1; then compounds 2 and 3 (each within the scatter of the next).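

In this assay the core itself proves sensitive to change: with the 2-fluorophenyl kept, methoxy in place of hydrogen on an aromatic carbon of the fused system, meta to a fused ring and para to a fused ring, gives a 9.3-fold higher number from compound 1 to compound 3 (0.97 log units; beyond the scatter). Compound 1 and compound 2 differ only in the fluorophenyl, so they said nothing about this place, and the step there, a 5.9-fold higher number from compound 1 to compound 2 (0.77 log units; beyond the scatter), now has a counterpart on the core that also runs towards a higher number. No measured evidence is available to explain this result.

As far as these compounds go, whether a smaller group such as methyl, or a chlorine or hydroxy group, would behave like methoxy at this place remains open. Also open, from the compounds shown here alone, is whether methoxy gives a similar step when 3,4-difluorophenyl stands in place of 2-fluorophenyl.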